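This account rests on a few compounds, and the source may have more. Where it says the series, first, only, none or still open, it means among the compounds named here.

Measured compounds in an assay on VSM-A10 cells for antagonist activity at Endothelin-1 receptor (Rattus norvegicus); on this read-out higher numbers stand for weaker inhibition and lower numbers for stronger inhibition:
compound 1, `Cc1noc(NS(=O)(=O)c2ccc(NC(=O)CN)cc2)c1C`: 6500 nM
compound 2, `Cc1noc(NS(=O)(=O)c2cccc3c(N4CCCC4=O)cccc23)c1C`: 130 nM

Compound 1 gives the higher of the two numbers in this assay; its nearest neighbour in value is compound 2, which gives the lower of the two, and the gap between them is beyond the usual scatter. No direct single-point comparison links compound 1 and compound 2, so their two values are recorded side by side without further reading.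

Compound 3, `Cc1noc(NS(=O)(=O)c2ccc(NC(=O)Nc3ccccc3)cc2)c1C`, is not yet measured in this assay. It differs from compound 1 in one place: anilino in place of aminomethyl on a carbonyl carbon. The aminomethyl on the carbonyl carbon is replaced by anilino, so the substituent on the amide-type nitrogen grows from two heavy atoms to seven and gains a six-membered aromatic ring of carbon only.

Among the measured compounds shown here, with no measured pair of this kind to lean on, the expectation rests on compound 1 alone. Starting from compound 1 at 6500 nM, the step is expected to run toward a lower number, a 4.3-fold lower number from compound 1 to compound 3 (0.64 log units; beyond the scatter), of modest size and not far beyond the scatter. Compound 3 is accordingly estimated at 1500 nM in this assay, with a range from 300 nM to 8000 nM.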

Compound 3, half-maximal inhibitory concentration: 38000 nM
Estimate against measurement, compound 3: 25-fold (1.40 log units) below; the measured number lies above the stated range.
By their numbers in this assay, from the lowest: compound 2; then compound 1; then compound 3.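

Among the compounds shown here, replacing aminomethyl with anilino on a carbonyl carbon gives, in this assay, a 5.8-fold higher number from compound 1 to compound 3 (0.77 log units; beyond the scatter), the first single-place step, and it runs toward weaker inhibition. On this one pair, a larger substituent carrying a six-membered aromatic ring of carbon only brings no gain at this place, and the direction is clear even though the step is modest. The change also swaps several features at once, going from aminomethyl with 1 hydrogen-bond acceptor to anilino with 0 hydrogen-bond acceptors while adding the ring and heavy atoms, and nothing available here assigns the step to any one of these differences.

The compounds shown leave open how the read-out responds to each of those features taken separately, for which a small methyl group, a longer chain ending in an amine, or a benzyl group on the same carbonyl carbon would be informative. Also open, as far as these compounds go, is whether a carboxylic acid at this place, or a substituted phenyl ring in the anilino group, would move the number in either direction on the core of compound 1.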